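This account rests on a few compounds, and the source may have more. Where it says the series, first, only, none or still open, it means among the compounds named here.

Compounds 1, 2 and 3 share one core and differ only in the group on a saturated ring carbon. In an ADME assay on HeLa cells (Homo sapiens) for cytotoxicity (on this read-out lower numbers stand for stronger inhibition and higher numbers for weaker inhibition), compound 1 (`Cc1ncc([N+](=O)[O-])n1CCSC(=S)N1CCC(O)CC1`) gives 930 ug/mL. Compound 2 (`Cc1ncc([N+](=O)[O-])n1CCSC(=S)N1CCC(OS(C)(=O)=O)CC1`) reaches only a limit of the assay in this assay, > 1000 ug/mL. Compound 3 (`CCOC(=O)C1CCN(C(=S)SCCn2c([N+](=O)[O-])cnc2C)CC1`) gives 510 ug/mL in this assay, the smaller of the two numbers shown, though its gap to compound 1 lies within the scatter. Both steps leading to compound 3, a 1.8-fold lower number from compound 1 to compound 3 (0.26 log units; within the scatter) and an at least 1.9-fold lower number from compound 2 to compound 3 (0.29 log units; that floor lies within the scatter), swap the group on that ring carbon without leaving the scatter. Compound 4 (`Cc1ncc([N+](=O)[O-])n1CCSC(=S)N1CCC(OC(=O)CN2CCCCC2)CC1`) swaps it again: (((piperidin-1-yl)methyl)carbonyl)oxy in place of ethoxycarbonyl on a saturated ring carbon. Within the data shown here, no measured step mirrors this exact change, so no shift beyond the scatter is expected, a 1.1-fold higher number from compound 3 to compound 4 (0.03 log units; within the scatter). Compound 4 is estimated at 550 ug/mL, between 280 ug/mL and 1100 ug/mL.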

Compound 4, half-maximal inhibitory concentration: 760 ug/mL
Estimate against measurement, compound 4: 1.4-fold (0.14 log units) below; measured number inside the range.
By their numbers in this assay, from the lowest: compounds 3, 4 and 1 (each within the scatter of the next). At a limit, above all of these: compound 2.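

Even the large (((piperidin-1-yl)methyl)carbonyl)oxy group, which brings a six-membered ring with a nitrogen to this saturated ring carbon, moves the number no further than the scatter, whether it replaces ethoxycarbonyl (a 1.5-fold higher number from compound 3 to compound 4 (0.17 log units; within the scatter)) or the hydrogen on the oxygen (a 1.2-fold lower number from compound 1 to compound 4 (0.09 log units; within the scatter)). Against compound 2 only a floor can be read (an at least 1.3-fold lower number from compound 2 to compound 4 (0.11 log units; that floor lies within the scatter)), and compound 2 stands at a limit: the limit of > 1000 ug/mL in this assay, at which 1 of the 4 values shown sits. Going by these compounds, whether a free amine or a carboxylic acid on this ring carbon would give a step beyond the scatter remains open.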